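Reversing the amide on an aryl-oxazole fragment

The source may hold more compounds than are shown below. What is called first, only, known or untested is meant among the compounds shown, and "the series" means these compounds.

Measured compounds:
compound 1, `Fc1ccccc1Nc1nc(-c2ccccc2)cs1`: < 1000 nM
compound 2, `CNC(=O)c1cccc(-c2cnc(Nc3ccc(F)cc3)o2)c1`: 3100 nM

Of the compounds shown here, two have been measured in a physicochemical assay for solubility, using the shake flask method, measured as kinetic solubility, at pH 7.4; on this read-out higher numbers stand for higher solubility and lower numbers for lower solubility. For compound 1 the result is a limit of the assay and not a number, namely < 1000 nM. Within the data shown here, compound 2 is therefore the only compound with an actual number here, giving 3100 nM in this assay, and there is no measured step between two compounds that differ in just one place. Among the measured compounds shown here, the one piece of evidence on the measured side is the limit of < 1000 nM in this assay, at which 1 of the 2 values shown sits.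

Compound 3, `CC(=O)Nc1cccc(-c2cnc(Nc3ccc(F)cc3)o2)c1`, is not yet measured. It differs from compound 2 by acetamido in place of methylcarbamoyl on an aromatic carbon; the two compounds contain the same atoms, joined differently. For the measured compounds named here, with no measured step of this kind to lean on, the expectation is a change that stays within the usual scatter, in no particular direction, so the step from compound 2 to compound 3 is estimated as a 1.0-fold lower number from compound 2 to compound 3 (0.01 log units; within the scatter). Compound 3 is accordingly expected to reach about 3000 nM in this assay, with a likely range from 1000 nM to 9000 nM.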

Compound 3, solubility: 5000 nM
The estimate for compound 3 lay 1.7-fold (0.22 log units) below the measured number; the range from low to high includes it.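

In this assay, among these compounds, reversing the amide gives the first measured step between two compounds that differ in just one place: a 1.6-fold higher number from compound 2 to compound 3 (0.21 log units; within the scatter). The two groups, methylcarbamoyl and acetamido, contain the same atoms and match in every count computed for them, and at this position, on an aromatic carbon meta to a large group, the assay does not tell the two amide directions apart. Among the compounds shown here, the measured evidence offers no explanation for how closely the two results agree, and the one limit among the values concerns a compound that differs from these two in more than one place.

This single pair leaves open what a group of a different kind would do at the same position, such as a primary amine, a carboxylic acid or a longer chain like propionamido in place of acetamido. It also leaves open whether reversing the amide would read the same way at another position on the ring or on a different core, such as the core of compound 1.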